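Benzamide substituent changes on the shared core

A few compounds are considered here, and "the series" means these few. Any claim that something is new, unique, unknown or untested is made for them only; others in the source may bear on it.

Compound 3 `CN1CCN(c2ccc(Nc3nc(-c4cccc(NC(=O)c5ccc(F)cc5)c4)sc3C(N)=O)cc2)CC1` gives 2820 nM in a functional assay on Raji cells (Homo sapiens) for antiproliferative activity, read by CCK-8 assay, with a stated time of 72 h (on this read-out lower numbers stand for stronger inhibition and higher numbers for weaker inhibition), and compound 2 `CN1CCN(c2ccc(Nc3nc(-c4cccc(NC(=O)c5ccc(C(F)(F)F)cc5)c4)sc3C(N)=O)cc2)CC1` gives 3210 nM; the two numbers sit within the scatter of each other, as the step of a 1.1-fold lower number from compound 2 to compound 3 (0.06 log units; within the scatter) shows. For compound 1 `CN1CCN(c2ccc(Nc3nc(-c4cccc(NC(=O)c5ccccc5)c4)sc3C(=O)O)cc2)CC1` the result in this assay is "not determined" (no result reported). Compound 4 `CN1CCN(c2ccc(Nc3nc(-c4cccc(NC(=O)c5ccccc5)c4)sc3C(N)=O)cc2)CC1` carries hydrogen in place of fluoro on an aromatic carbon, in words hydrogen in place of fluoro on an aromatic carbon. For the measured compounds named here, the only measured step that bears on this change is the one from compound 2 to compound 3, which was within the scatter, so for compound 4 the expected step is a 1.0-fold higher number from compound 3 to compound 4 (0.01 log units; within the scatter), with no shift beyond the scatter anticipated in either direction. Compound 4 is therefore estimated at 2900 nM in this assay, within a range of 1200 nM to 7000 nM.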

Compound 4, half-maximal inhibitory concentration: 6360 nM
Beside the measured number, compound 4's estimate is 2.2-fold (0.34 log units) below it; the range from low to high includes it.
By their numbers in this assay, from the lowest: compounds 3, 2 and 4 (each within the scatter of the next, the first and the last beyond it).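

Hydrogen in place of fluoro gives a 2.3-fold higher number from compound 3 to compound 4 (0.35 log units; beyond the scatter) in this assay and is the first change at this position to pass the scatter, though only modestly. Hydrogen in place of trifluoromethyl gives a 2.0-fold higher number from compound 2 to compound 4 (0.30 log units; within the scatter) and stays within the scatter, so the benzamido compound separates from the 4-fluorophenyl compound only. No measured evidence accounts for this difference.

As far as these compounds go, whether an amine or a methoxy group at this aromatic carbon would track with fluoro or with hydrogen remains open. Also open, from the compounds shown here alone, is whether a substituent here can bring the number well below those of compounds 2 and 3.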